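Lengthening the Amide Chain in a Cytotoxic Anilide Series

The source may report more compounds than this note shows. Statements on the series, on what has been measured and on what is new or still open speak of the compounds shown alone.

Going by the values given here, compound 2 `CCCC(=O)N1c2ccccc2CCC1C(=O)Nc1cc(C(F)(F)F)cc(C(F)(F)F)c1` is the only compound here with a definite number in a functional assay on NUGC-3 cells (Homo sapiens) for cytotoxicity, read by sulforhodamine B assay, with a stated time of 72 h; on this read-out higher numbers stand for weaker inhibition of growth and lower numbers for stronger inhibition of growth: compound 2 gives 14400 nM. Compound 1 `CC(=O)N1c2ccccc2CCC1C(=O)Nc1cc(C(F)(F)F)cc(C(F)(F)F)c1` reaches only a limit in this assay, > 70000 nM (the limit of > 70000 nM in this assay, at which 1 of the 3 values shown sits). Compound 3 `CCC(=O)N1c2ccccc2CCC1C(=O)Nc1ccccc1C(F)(F)F` likewise stops at a limit, > 80000 nM (the limit of > 80000 nM in this assay, at which 1 of the 3 values shown sits). Among the compounds with values here, the one step that can be sized, an at least 4.8-fold lower number from compound 1 to compound 2 (0.68 log units; beyond the scatter), points toward stronger inhibition of growth when the chain on the carbonyl grows. Compound 4 `CCCCCCCCC(=O)N1c2ccccc2CCC1C(=O)Nc1cc(C(F)(F)F)cc(C(F)(F)F)c1` carries that chain further: pentyl in place of hydrogen on a saturated chain carbon, three bonds along the chain from a carbonyl carbon. Within the data shown here, only the step from compound 1 to compound 2 bears on this change, so the expected step of a 2.4-fold lower number from compound 2 to compound 4 (0.38 log units; beyond the scatter) is modest and in the same direction, though a chain this long has no measured precedent. Compound 4 is therefore expected to give 6000 nM, within 1500 nM to 30000 nM.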

Compound 4, concentration for 50% growth inhibition: 2230 nM
For compound 4 the middle estimate is 2.7-fold (0.43 log units) above the measured one, within the range that was stated.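

Adding pentyl to the chain on the carbonyl in this assay gives a 6.5-fold lower number from compound 2 to compound 4 (0.81 log units; beyond the scatter), so the gain from the first lengthening carries on further along the chain. Over the full lengthening, the change is an at least 31-fold lower number from compound 1 to compound 4 (1.49 log units; beyond the scatter). Compound 1 gives only a limit, > 70000 nM.

Nothing shown here explains why the longer chain goes with stronger inhibition of growth. As far as these compounds go, it also remains open whether a still longer chain, or an amine or carboxylic acid at the end of this one, would strengthen inhibition further.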